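Swapping a ring for an open chain on compound 3

The source may report more compounds than this note shows. Statements on the series, on what has been measured and on what is new or still open speak of the compounds shown alone.

Measured so far in an ADME assay on microsomes from liver (Rattus norvegicus) for metabolic stability; on this read-out lower numbers stand for a shorter-lived compound and higher numbers for a longer-lived compound
Compound 1 `CC(C)C(c1ncco1)c1ccc(-c2ccc3cccc(F)c3c2)[nH]c1=O` gives 0.0983 h
Compound 2 `CC(C)C(Cc1nnn[nH]1)c1ccc(-c2ccc3cccc(F)c3c2)[nH]c1=O` gives 2.08 h
Compound 3 `CC(C)C(/C=C1/CCNC1=O)c1ccc(-c2ccc3cccc(F)c3c2)[nH]c1=O` gives 0.06 h

Compound 3 stands at 0.06 h on the short-lived side of these numbers. It lies within the scatter of compound 1 (the step is a 1.6-fold lower number from compound 1 to compound 3 (0.21 log units; within the scatter)), while the gap to compound 2 is large (the step is a 35-fold lower number from compound 2 to compound 3 (1.54 log units; beyond the scatter)).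

Compound 4 `CC(C)NC(=O)CC(c1ccc(-c2ccc3cccc(F)c3c2)[nH]c1=O)C(C)C` keeps the shared core but carries (isopropylcarbamoyl)methyl, with no ring, on the saturated chain carbon (the change is a group of 7 heavy atoms (5 carbon, 1 nitrogen, 1 oxygen; no ring) in place of a group of 7 heavy atoms (5 carbon, 1 nitrogen, 1 oxygen; one five-membered non-aromatic ring with 1 hetero atom), on a saturated chain carbon bound to an aromatic carbon and a saturated chain carbon).

All three measured steps concern this same place. The large rise came with (1H-tetrazol-5-yl)methyl (the step is a 21-fold higher number from compound 1 to compound 2 (1.33 log units; beyond the scatter)), and compound 4 lacks that group. Compound 1 and compound 3 carry quite different groups, yet stay within the scatter of each other. Three compounds are a thin basis, and none of them carries the new group. In this assay no step beyond the scatter is therefore expected (the estimated step is a 1.5-fold higher number from compound 3 to compound 4 (0.18 log units; within the scatter)). The estimate for compound 4 is 0.09 h (expected range 0.035 h to 0.3 h).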

Compound 4, half-life: < 0.0667 h
Compound 4: no number, only a limit; the forecaster's own chance of this, stated with the estimate: 3%; at least 1.3-fold (0.13 log units) between middle value and limit.
By their numbers in this assay, from the lowest: compounds 3 and 1 (each within the scatter of the next); then compound 2.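

In this assay compound 4 reads only as a limit of the assay, not as a number: the limit of < 0.0667 h in this assay, at which 1 of the 4 values shown sits. Even so, the open chain of (isopropylcarbamoyl)methyl on this saturated chain carbon gives a large gap, with an at least 31-fold lower number from compound 2 to compound 4 (1.49 log units; beyond the scatter), so a ring-free group here does not by itself bring a long-lived compound. The comparison with the 1,3-oxazol-2-yl group shows an at least 1.4-fold lower number from compound 1 to compound 4 (0.16 log units; that floor lies within the scatter), while the step from compound 3 to compound 4 cannot be read.

On these data alone, the true value of compound 4 stays unknown, so no order can be set between compound 3 and compound 4. Also open, as far as these compounds go, is whether a carboxylic acid or an amine at this place would come closer than the isopropylcarbamoyl group to compound 2 at 2.08 h.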